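Working notes: from compound 1 to compound 4

The source may report more compounds than this note shows. Statements on the series, on what has been measured and on what is new or still open speak of the compounds shown alone.

- compound 1 `C=CCC(O)(c1ccc(OC)c(OC)c1OC)c1cccc2ccccc12`: > 20000 nM
- compound 2 `COc1ccc(/C(=N/OCC(=O)O)c2cccc3ccccc23)c(OC)c1OC`: > 20000 nM
- compound 3 `COc1cc(COC(c2ccc(OC)c(OC)c2OC)c2cccc3ccccc23)cc(OC)c1`: > 20000 nM

All three readings come from a functional assay on THP-1 cells (Homo sapiens) for inhibition, read by sulforhodamine B assay, with a stated time of 48 h (on this read-out higher numbers stand for weaker inhibition and lower numbers for stronger inhibition), and each is a limit, not a number. Compound 1 stands at > 20000 nM, which is a limit. Going by the values given here, the other two compounds offer no numerical comparison, and the series so far reads as follows: the limit of > 20000 nM in this assay, at which 3 of the 3 values shown sit.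

Compound 4 `COc1ccc(C(O)(Cc2ccccc2)c2cccc3ccccc23)c(OC)c1OC` keeps the core of compound 1 and changes one group: phenyl in place of vinyl on a saturated chain carbon, two bonds along the chain from two aromatic carbons and an oxygen on a saturated carbon. In words, this is phenyl in place of vinyl on a saturated chain carbon, and cut one bond further out it reads allyl to benzyl. Among the compounds with values here, no measured pair gives the size of a single change. The expected step of a number no higher from compound 1 to compound 4 (the limit leaves the size open) is none beyond the scatter, with no direction favoured. That expectation rests on compound 1, whose limit is > 20000 nM. Another reading at the limit is the likeliest outcome in this assay. Compound 4 is estimated at 20000 nM, with an expected range of 5000 nM to 40000 nM.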

Compound 4, half-maximal inhibitory concentration: 12400 nM
For compound 4 the middle estimate is 1.6-fold (0.21 log units) above the measured one, within the range that was stated.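

Going by these compounds alone, on the saturated chain carbon, phenyl in place of vinyl gives the only actual number so far: in this assay compound 4 reads 12400 nM. The change from allyl to benzyl can be stated only as an at least 1.6-fold lower number from compound 1 to compound 4 (0.20 log units; that floor lies within the scatter); this is a floor within the scatter, so the data show neither a real shift nor its true size. Even so, this position accepts the phenyl ring with a reading that is not a limit, and compound 4 stands apart from the other values shown: the limit of > 20000 nM in this assay, at which 3 of the 4 values shown sit.

As far as these compounds go, how an amine or a longer chain ending in phenyl at this carbon would read in this assay stays open. Also open, from the compounds shown here alone, is how far the true value of compound 1 lies from its limit, and with it the real size of this step.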